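Trimming a Methoxy Pair to a Single Methoxy

The compounds below may be only part of what the source reports. "The series", "measured", "known", "first", "only" and "open" are said of these compounds alone.

Compound 1 `COc1ccc(CNCCCNS(=O)(=O)c2cc(C(F)(F)F)cc(C(F)(F)F)c2)cc1OC` is the stronger of two measured sulfonamides. In a functional assay on HPAC cells (Homo sapiens) for inhibition, read by MTT assay, with a stated time of 72 h (on this read-out higher numbers stand for weaker inhibition of growth and lower numbers for stronger inhibition of growth), compound 1 gives 3500 nM, while compound 2 `O=S(=O)(NCCNCc1cccc2ccccc12)c1cc(C(F)(F)F)cc(C(F)(F)F)c1` gives 18000 nM, a gap beyond the usual scatter. Compound 3 `COc1ccccc1CNCCCNS(=O)(=O)c1cc(C(F)(F)F)cc(C(F)(F)F)c1` has not yet been measured; it differs from compound 1 by one change: 2-methoxyphenyl in place of 3,4-dimethoxyphenyl on a saturated chain carbon bound to an amine nitrogen. Among the compounds with values here, no measured pair shows the effect of this change, so only a modest shift is expected in this assay, most likely toward weaker inhibition, with the step of a 1.4-fold higher number from compound 1 to compound 3 (0.15 log units; within the scatter) expected to stay near the scatter. For compound 3 the estimate is 5000 nM, with a range from 1500 nM to 16000 nM.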

Compound 3, concentration for 50% growth inhibition: 2400 nM
Compound 3: middle estimate off by 2.1-fold (0.32 log units), on the high side, and the stated range covers the measured number.
By their numbers in this assay, from the lowest: compounds 3 and 1 (each within the scatter of the next); then compound 2.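

On a saturated chain carbon bound to an amine nitrogen, 2-methoxyphenyl can replace 3,4-dimethoxyphenyl in this assay with only a 1.5-fold lower number from compound 1 to compound 3 (0.16 log units; within the scatter), so for this pair, one methoxy group serves as well as two. The change removes a hydrogen-bond acceptor, and the reading stays within the scatter. No measured evidence explains why the two compounds read alike. Going by these compounds, whether any methoxy group is needed remains open, since a plain phenyl here could read differently. An amine or a carboxylic acid on the ring, or a longer chain, also remains untested among the compounds shown.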